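Bromomethyl to Trifluoromethyl: Expected Cell Tolerance of Compound 3

A few compounds are considered here, and "the series" means these few. Any claim that something is new, unique, unknown or untested is made for them only; others in the source may bear on it.

Compound 1 `O=C(O)c1ccc(-c2noc(CCl)n2)cc1`: 64000 nM
Compound 2 `O=C(O)c1ccc(-c2noc(CBr)n2)cc1`: 81900 nM

In an ADME assay on MT2 cells (Homo sapiens) for cytotoxicity, read by XTT assay, with a stated time of 4 days (a higher number here means that more compound is tolerated, a lower number that less compound is tolerated), compound 1 gives 64000 nM, while compound 2 gives 81900 nM. Compound 2 thus holds the larger of the two numbers, but the step of a 1.3-fold higher number from compound 1 to compound 2 (0.11 log units; within the scatter) is within the scatter, so the two compounds are tolerated alike. Compound 3 `O=C(O)c1ccc(-c2noc(C(F)(F)F)n2)cc1` differs from compound 2 by trifluoromethyl in place of bromomethyl on an aromatic carbon. Within the data shown here, the only measured step swaps one halogen for another on that chain carbon and says little about a change to a trifluoromethyl group. Compound 3 is therefore expected to move by a 1.3-fold higher number from compound 2 to compound 3 (0.13 log units; within the scatter), a modest rise. The estimated value of compound 3 is 110000 nM, within 45000 nM to 260000 nM.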

Compound 3, half-maximal cytotoxic concentration: 82300 nM
Compound 3: the middle estimate sits 1.3-fold (0.13 log units) above what was measured, within the range that was stated.
By their numbers in this assay, from the lowest: compounds 1, 2 and 3 (each within the scatter of the next).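

The earlier compounds shown here exchanged only one halogen for another on the chain carbon. Here the whole group on this aromatic carbon changes to trifluoromethyl, and this assay still reads alike, with a 1.0-fold higher number from compound 2 to compound 3 (0.00 log units; within the scatter) and a 1.3-fold higher number from compound 1 to compound 3 (0.11 log units; within the scatter), so neither chloromethyl nor bromomethyl is needed for the tolerance seen across these three compounds. Nothing available explains this sameness. The compounds shown leave open whether an amine, a hydroxyl or a longer chain at this position would shift the number in this assay, as all three groups here are small and halogen-bearing.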